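The source may hold more compounds than are shown below. What is called first, only, known or untested is meant among the compounds shown, and "the series" means these compounds.

Measured so far in a functional assay on K562 cells (Homo sapiens) for inhibition, read by MTT assay, with a stated time of 48 h; on this read-out higher numbers stand for weaker inhibition and lower numbers for stronger inhibition:
Compound 1, `CC(C)(C)C(=O)Nc1ccc(-c2ccc(C(=O)N[C@H]3CN[C@@H](C(=O)Nc4ccc(Cl)c(C(F)(F)F)c4)C3)cc2)cn1`: 11600 nM
Compound 2, `Nc1ccc(-c2ccc(C(=O)N[C@H]3CN[C@@H](C(=O)Nc4ccc(Cl)c(C(F)(F)F)c4)C3)cc2)cn1`: 9130 nM
Compound 3, `C[C@H](NC(=O)c1cccc(-c2ccc(NC(=O)C(C)(C)C)nc2)c1)C(=O)Nc1ccc(Cl)c(C(F)(F)F)c1`: 18400 nM

Compound 2 differs from compound 1 by hydrogen in place of (tert-butyl)carbonyl on a nitrogen on an aromatic ring, and the step is a 1.3-fold lower number from compound 1 to compound 2 (0.10 log units; within the scatter). Compound 3 carries a different core; the difference between the two cores is not broken down here. In this assay compound 3 lies within the scatter of both compound 1 and compound 2, so no order among the three is claimed.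

Compound 4, `C[C@H](NC(=O)c1cccc(-c2ccc(N)nc2)c1)C(=O)Nc1ccc(Cl)c(C(F)(F)F)c1`, is not yet measured. It differs from compound 3 by hydrogen in place of (tert-butyl)carbonyl on a nitrogen on an aromatic ring, the same change at the same kind of place as that from compound 1 to compound 2. For compound 4 the step is expected to be a 1.3-fold lower number from compound 3 to compound 4 (0.10 log units; within the scatter), resting on the earlier step of a 1.3-fold lower number from compound 1 to compound 2 (0.10 log units; within the scatter), with added uncertainty because that step was seen on a different core. Compound 4 is estimated at 14500 nM, with a likely range from 6000 nM to 36000 nM.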

Compound 4, half-maximal inhibitory concentration: 8090 nM
The estimate for compound 4 lay 1.8-fold (0.25 log units) above the measured number; low and high end bracket the measured number.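

In this assay, hydrogen in place of (tert-butyl)carbonyl on a nitrogen on an aromatic ring gives a 2.3-fold lower number from compound 3 to compound 4 (0.36 log units; beyond the scatter). Set beside the same change on the other core, the two steps cannot be told apart: the same change on two cores in this assay, a 1.3-fold lower number (0.10 log units; within the scatter) from compound 1 to compound 2 and a 2.3-fold lower number (0.36 log units; beyond the scatter) from compound 3 to compound 4, 1.8-fold (0.25 log units) apart, within the scatter of two such steps. The change therefore carries across these two cores without a detectable difference in size, but with a single pair on each core this does not show that the two steps are equal or that the change would behave alike on any further core.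

Open, from the compounds shown here alone, is how smaller or different groups on that nitrogen, such as acetyl or methyl, would compare with hydrogen and (tert-butyl)carbonyl. Also open, going by these compounds, is whether a longer acyl chain there would fit the same picture on either core.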